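The compounds below may be only part of what the source reports. "The series", "measured", "known", "first", "only" and "open" are said of these compounds alone.

Of the compounds shown here, three sharing one core have been tested in a functional assay on BGC-823 cells (Homo sapiens) for antiproliferative activity, read by MTT assay; on this read-out lower numbers stand for stronger inhibition and higher numbers for weaker inhibition. Compound 1 `Cc1cccc(NC(=O)/C(C#N)=C/c2cc(O)c(O)c([N+](=O)[O-])c2)c1` gives 5.6 ug/mL, and compound 2 `N#C/C(=C\c1cc(O)c(O)c([N+](=O)[O-])c1)C(=O)Nc1ccccc1Cl` gives 10.5 ug/mL; the step of a 1.9-fold higher number from compound 1 to compound 2 (0.27 log units; within the scatter) is within the scatter. Compound 3 `N#C/C(=C\c1cc(O)c(O)c([N+](=O)[O-])c1)C(=O)N1CCCCC1` reaches only the limit of the assay, > 100 ug/mL, so for compound 3 no number is known, only that it sits at the limit of > 100 ug/mL in this assay, at which 1 of the 3 values shown sits. Measured against the two anilides, the step of an at least 17-fold higher number from compound 1 to compound 3 (1.25 log units; beyond the scatter) and the step of an at least 9.5-fold higher number from compound 2 to compound 3 (0.97 log units; beyond the scatter) both lie beyond the scatter, so the group on the carbonyl carbon clearly matters in this assay.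

Compound 4 `N#C/C(=C\c1cc(O)c(O)c([N+](=O)[O-])c1)C(N)=O` has not been measured. It differs from compound 3 by amino in place of piperidin-1-yl on a carbonyl carbon. Among the compounds with values here, no measured step exchanges piperidin-1-yl for a plain amino group, so the size and direction of this step cannot be read from the data directly. What the two steps into compound 3 show is that leaving an arylamino for piperidin-1-yl costs a great deal; the move to amino is a different change, and because compound 3 stands at the limit of > 100 ug/mL in this assay, at which 1 of the 3 values shown sits, the step of an at least 3.3-fold lower number from compound 3 to compound 4 (0.52 log units; beyond the scatter) can only be guessed. A middling value is expected for compound 4, around 30 ug/mL, somewhere between 5 ug/mL and 100 ug/mL.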

Compound 4, half-maximal inhibitory concentration: > 100 ug/mL
Compound 4: only a limit was reported (the forecaster's own chance of this, stated with the estimate: 40%); middle value at least 3.3-fold (0.52 log units) away from the limit.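

In this assay, hydrogen in place of 3-methylphenyl on the amide-type nitrogen gives an at least 17-fold higher number from compound 1 to compound 4 (1.25 log units; beyond the scatter), and hydrogen in place of 2-chlorophenyl on that nitrogen gives an at least 9.5-fold higher number from compound 2 to compound 4 (0.97 log units; beyond the scatter). Compound 3 has no amide hydrogen, so its result alone left open whether losing that hydrogen explained the drop; compound 4 keeps the amide hydrogen, as do compound 1 and compound 2, yet it too fails to give a measurable value, so the amide hydrogen alone is not enough for activity here. No order can be given for compound 3 and compound 4, and the step from one to the other cannot be read, because both are limits and not numbers: the limit of > 100 ug/mL in this assay, at which 2 of the 4 values shown sit.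

Among these four compounds, only the two with an aryl group on the amide nitrogen give measurable values, but it remains open whether the aromatic ring itself is what counts. A cyclohexylamino group would test a ring that is not aromatic on an amide nitrogen that keeps its hydrogen, and a benzylamino group would test an aromatic ring set one carbon further from that nitrogen.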